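The source may hold more compounds than are shown below. What is called first, only, known or untested is meant among the compounds shown, and "the series" means these compounds.

Three of these four compounds have been tested in a functional assay, read by Griess assay, with a stated time of 150 min, tested at 100 ug/mL; on this read-out higher numbers stand for a stronger effect at the one concentration tested and lower numbers for a weaker effect. Compound 1, `COc1ccc(C2=NOC(c3ccc(C)cc3)C2S(=O)(=O)CC2=NCCO2)cc1`, gives 71.3%, and compound 3, `COc1ccc(C2=NOC(c3ccc(C)cc3)C2S(=O)(=O)CC2=NCCS2)cc1`, gives 59.6%. The two differ only in the group attached to the sulfonyl arm: a group of 5 heavy atoms (3 carbon, 1 nitrogen, 1 oxygen; one five-membered non-aromatic ring with 2 hetero atoms) in place of a group of 5 heavy atoms (3 carbon, 1 nitrogen, 1 sulfur; one five-membered non-aromatic ring with 2 hetero atoms), on a saturated chain carbon bound to a sulfonyl sulfur. Among the compounds with values here, that step, a number 11.7 percentage points higher from compound 3 to compound 1 (beyond the scatter), is the one change in this set with a known size.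

Compound 2, `COc1ccc(-c2noc(-c3ccc(C)cc3)c2S(=O)(=O)CC2=NCCS2)cc1`, carries a different core from compound 3; the difference between the two cores is not broken down here. In this assay compound 2 was recorded as "not active" (no number reported), so no number stands for it.

Compound 4, `COc1ccc(-c2noc(-c3ccc(C)cc3)c2S(=O)(=O)CC2=NCCO2)cc1`, has not yet been measured. It relates to compound 2 exactly as compound 1 relates to compound 3, the same change at the same place: a group of 5 heavy atoms (3 carbon, 1 nitrogen, 1 oxygen; one five-membered non-aromatic ring with 2 hetero atoms) in place of a group of 5 heavy atoms (3 carbon, 1 nitrogen, 1 sulfur; one five-membered non-aromatic ring with 2 hetero atoms), on a saturated chain carbon bound to a sulfonyl sulfur. Carrying the earlier step over, a modest rise from compound 2 is expected, but since compound 2 showed no measurable effect, compound 4 is expected to remain weak, at about 12%, somewhere between 0% and 35%, with a real chance that only "not active" is reported again.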

Compound 4, a percentage reported as activity, at one concentration (the size of the read-out at that concentration, not a potency): 76.2%
For compound 4 the middle estimate is 64.2 percentage points below the measured one; the whole stated range lies below it.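

Within the data shown here, compound 2 has no number, only the record "not active", so no step from compound 2 to compound 4 can be read. Nothing available bears on what lies behind the result for compound 4. The compounds shown leave open whether the change of group has the same size on the core of compound 4 as on the core of compound 1.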